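A few compounds are considered here, and "the series" means these few. Any claim that something is new, unique, unknown or untested is made for them only; others in the source may bear on it.

In a functional assay on A549 cells (Homo sapiens) for antiproliferative activity, read by MTT assay, with a stated time of 72 h (a higher number here means a weaker inhibitor, a lower number a stronger inhibitor), compound 1 `COc1cc2ncnc(Nc3ccc(Cl)c(C(F)(F)F)c3)c2cc1OCCCCC(=O)Nc1ccc(S(N)(=O)=O)cc1` gives 9270 nM, the lowest of the two numbers recorded in this set. Compound 2 `COc1cc2ncnc(Nc3cccc(Cl)c3)c2cc1OCCCCC(=O)Nc1ccc(S(N)(=O)=O)cc1` gives 11200 nM; the change here is a 1.2-fold higher number from compound 1 to compound 2 (0.08 log units; within the scatter). Compound 3 `COc1cc2ncnc(Nc3ccc(Cl)cc3)c2cc1OCCCCC(=O)Nc1ccc(S(N)(=O)=O)cc1` reaches only a limit of the assay, > 40000 nM. One recorded value is therefore (the limit of > 40000 nM in this assay, at which 1 of the 3 values shown sits). Against it, an at least 4.3-fold higher number from compound 1 to compound 3 (0.63 log units; beyond the scatter) and an at least 3.5-fold higher number from compound 2 to compound 3 (0.55 log units; beyond the scatter). Compound 4 `COc1cc2ncnc(Nc3cccc(Cl)c3F)c2cc1OCCCCC(=O)Nc1ccc(S(N)(=O)=O)cc1` differs from compound 1 by 3-chloro-2-fluorophenyl in place of 4-chloro-3-(trifluoromethyl)phenyl on a nitrogen on an aromatic ring. The swap to 3-chlorophenyl bears on this and stayed within the scatter, whereas loss of the trifluoromethyl gave an at least modest weakening; here 3-chlorophenyl is kept and a fluorine enters. A number near compound 2, or somewhat higher, is expected, a 1.4-fold higher number from compound 1 to compound 4 (0.15 log units; within the scatter). Compound 4 is estimated at 13000 nM, between 5000 nM and 35000 nM.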

Compound 4, half-maximal inhibitory concentration: 10500 nM
Beside the measured number, compound 4's estimate is 1.2-fold (0.09 log units) above it; the range from low to high includes it.
By their numbers in this assay, from the lowest: compounds 1, 4 and 2 (each within the scatter of the next). At a limit, above all of these: compound 3.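

In this assay, fluoro in place of hydrogen on an aromatic carbon leaves the number level, a 1.1-fold lower number from compound 2 to compound 4 (0.03 log units; within the scatter), so this 3-chlorophenyl series tolerates a fluorine on the ring. The exchange for 4-chloro-3-(trifluoromethyl)phenyl is also level, a 1.1-fold higher number from compound 1 to compound 4 (0.05 log units; within the scatter), showing a second 3-chloro-containing group that matches compound 1 without trifluoromethyl. Compound 3 is only a limit, and the step to the new group is a bound, an at least 3.8-fold lower number from compound 3 to compound 4 (0.58 log units; beyond the scatter): the limit of > 40000 nM in this assay, at which 1 of the 4 values shown sits.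

Still open, as far as these compounds go, is whether 3-bromophenyl or 3-methylphenyl on this nitrogen would stay level with compound 2. Also open, from the compounds shown here alone, is whether a shorter chain would move the number at all.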